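Working notes: cyclopropyl replaces hydrogen on compound 1

The source may report more compounds than this note shows. Statements on the series, on what has been measured and on what is new or still open speak of the compounds shown alone.

Measured so far:
compound 1 `CN1Cc2cc(ccc2S(=O)(=O)C2CC2)NC(=O)CCc2cccc(c2)[C@@H](Nc2ccc3c(N)ncc(F)c3c2)C1=O` — 0.55 h
compound 2 `CN1CCc2cccc(c2)[C@@H](Nc2ccc3c(N)ncc(F)c3c2)C(=O)N(C)Cc2cc(ccc2S(=O)(=O)C2CC2)NC1=O` — 0.1 h

In an ADME assay on liver (Rattus norvegicus) for metabolic stability, using microsomes (on this read-out lower numbers stand for a shorter-lived compound and higher numbers for a longer-lived compound), compound 1 gives 0.55 h, the higher of the two numbers measured to date. Among the measured compounds shown here, compound 2 gives 0.1 h in this assay, a lower number that lies beyond the usual scatter of repeated measurements; no single-point step connects the two, so only the bare values are comparable.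

Compound 3 `CN1Cc2cc(ccc2S(=O)(=O)C2CC2)NC(=O)CCc2cc(ccc2C2CC2)[C@@H](Nc2ccc3c(N)ncc(F)c3c2)C1=O` is not yet measured. It differs from compound 1 by cyclopropyl in place of hydrogen on an aromatic carbon. For the measured compounds named here, no measured pair carries this change, and the two measured values offer no guide to it.

The step is therefore expected to be a 1.1-fold lower number from compound 1 to compound 3 (0.04 log units; within the scatter), none beyond the scatter, as a neutral working assumption. Compound 3 is estimated at 0.5 h, with a range from 0.2 h to 1.3 h.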

Compound 3, half-life: 0.0833 h
Beside the measured number, compound 3's estimate is 6.0-fold (0.78 log units) above it; measured number below the stated range.
By their numbers in this assay, from the lowest: compounds 3 and 2 (each within the scatter of the next); then compound 1.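

In this assay, among the compounds shown here, this aromatic carbon of the core of compound 1 does not tolerate every change: cyclopropyl in place of hydrogen gives a 6.6-fold lower number from compound 1 to compound 3 (0.82 log units; beyond the scatter), the first single-place step and one beyond the scatter. This is one substitution at one position, so it fixes the direction and size of the step for this group here, and it gives no rule for other groups or other positions. Nothing at hand bears on the cause of the step.

Open, going by these compounds, is whether a fluorine atom, a methyl group or a methoxy group on the same aromatic carbon would give a step of similar size in this assay. Also open, on these data alone, is whether cyclopropyl at this place would move the number for compound 2 in the same direction.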